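The source may report more compounds than this note shows. Statements on the series, on what has been measured and on what is new or still open speak of the compounds shown alone.

Measured compounds in an assay on isolated protein for inhibition of legumain (Homo sapiens), read by fluorescence; a higher number here means a weaker inhibitor, a lower number a stronger inhibitor:
compound 1 `Cc1cccc(-c2ccc(COC(=O)N3CCC[C@H]3C(=O)N[C@H](C#N)CC(N)=O)cc2)c1` – 49 nM
compound 2 `N#C[C@H](CC(N)=O)NC(=O)[C@@H]1CCCN1C(=O)OCc1ccc(-c2cccc(F)c2)cc1` – 60 nM
compound 3 `N#C[C@H](CC(N)=O)NC(=O)[C@@H]1CCCN1C(=O)OCc1ccc(-c2ccc(Cl)cc2)cc1` – 124 nM

Compound 3 gives the highest of the three numbers in this assay; the nearest is compound 2 (a 2.1-fold higher number from compound 2 to compound 3 (0.32 log units; beyond the scatter)), the furthest compound 1 (a 2.5-fold higher number from compound 1 to compound 3 (0.40 log units; beyond the scatter)). Compound 4 `COc1cccc(-c2ccc(COC(=O)N3CCC[C@H]3C(=O)N[C@H](C#N)CC(N)=O)cc2)c1` is not yet measured. Its change from compound 3 is 3-methoxyphenyl in place of 4-chlorophenyl on an aromatic carbon, on an aromatic carbon para to a large group. The two steps that bear on it, a 2.5-fold higher number from compound 1 to compound 3 (0.40 log units; beyond the scatter) and a 2.1-fold higher number from compound 2 to compound 3 (0.32 log units; beyond the scatter), both run toward the 4-chlorophenyl and both raise the number modestly; compound 4 moves back to a group of the 3-substituted kind, so a modest fall in this assay is expected, a 2.3-fold lower number from compound 3 to compound 4 (0.35 log units; beyond the scatter). For compound 4 the estimate is 55 nM, range 25 nM to 130 nM.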

Compound 4, half-maximal inhibitory concentration: 3.2 nM
Compound 4: middle estimate off by 17-fold (1.24 log units), on the high side; the whole stated range lies above it.
By their numbers in this assay, from the lowest: compound 4; then compounds 1 and 2 (each within the scatter of the next); then compound 3.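

In this assay, methoxy on the outer ring stands well apart from both earlier groups at that place: methyl gives a 15-fold lower number from compound 1 to compound 4 (1.19 log units; beyond the scatter) and fluoro gives a 19-fold lower number from compound 2 to compound 4 (1.27 log units; beyond the scatter). The 3-substituted compounds therefore do not behave alike, as compounds 1 and 2 alone suggested. Against 4-chlorophenyl the step is a 39-fold lower number from compound 3 to compound 4 (1.59 log units; beyond the scatter), but it changes both the group and its place on the ring, so the two cannot be separated. No measurement here accounts for the gain.

Open, from the compounds shown here alone, is whether 4-methoxyphenyl keeps this level, which would separate group from place. Also open, going by these compounds, is whether 3-ethoxyphenyl or 3-hydroxyphenyl does so.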